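Quinolinyl oxazolidinone CCR8 antagonists: benzothiophene to chlorobenzyl

This account rests on a few compounds, and the source may have more. Where it says the series, first, only, none or still open, it means among the compounds named here.

Measured compounds:
- compound 1, `COc1ccc2nccc(C3CN(CCCNCc4cc5ccccc5[nH]4)C(=O)O3)c2c1`: 1580 nM
- compound 2, `O=C1OC(c2ccc3ccccc3n2)CN1C1CCN(Cc2cc3ccccc3[nH]2)CC1`: < 50200 nM
- compound 3, `COc1ccc2nccc(C3CN(C4CCN(Cc5cc6ccccc6s5)CC4)C(=O)O3)c2c1`: 794 nM

Of the compounds shown here, three sharing a quinolinyl oxazolidinone core have been tested in an in vitro functional assay on RBL cells for antagonist activity at C-C chemokine receptor type 8 (Homo sapiens), read by FLIPR and calcium flux; a higher number here means a weaker inhibitor, a lower number a stronger inhibitor. Compound 1, `COc1ccc2nccc(C3CN(CCCNCc4cc5ccccc5[nH]4)C(=O)O3)c2c1`, carries a propylene linker to an indolylmethyl amine and gives 1580 nM. Compound 2, `O=C1OC(c2ccc3ccccc3n2)CN1C1CCN(Cc2cc3ccccc3[nH]2)CC1`, reaches only a limit of the assay, < 50200 nM; this is a limit and not a number (the limit of < 50200 nM in this assay, at which 1 of the 3 values shown sits). Compound 3, `COc1ccc2nccc(C3CN(C4CCN(Cc5cc6ccccc6s5)CC4)C(=O)O3)c2c1`, gives 794 nM, and this value and that of compound 1 lie within the usual scatter of each other, so no order between them can be read from the data.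

Compound 4, `COc1ccc2nccc(C3CN(C4CCN(Cc5ccccc5Cl)CC4)C(=O)O3)c2c1`, has not been measured. It differs from compound 3 in one place: 2-chlorophenyl in place of 1-benzothiophen-2-yl on a saturated chain carbon bound to an amine nitrogen in a ring. Among the measured compounds shown here, no measured pair in this set shows a comparable change, so the step can only be judged from the structures. The group that enters is smaller and lacks the hetero-atom ring of the group that leaves. The step from compound 3 to compound 4 is expected to be modest and toward a weaker inhibitor, a 2.0-fold higher number from compound 3 to compound 4 (0.30 log units; within the scatter). For compound 4 the estimate in this assay is 1600 nM, with a plausible range from 400 nM to 6300 nM.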

Compound 4, half-maximal inhibitory concentration: < 50200 nM
Compound 4: only a limit was reported; the forecaster's own chance of this, stated with the estimate: 10%; the middle value lies beyond the limit too.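

Compound 4 gives < 50200 nM as a limit of the assay and not a number. Among the compounds shown here, no step from compound 3 to compound 4 can therefore be read: the limit of < 50200 nM in this assay, at which 2 of the 4 values shown sit. The compounds shown leave open how large the difference between 1-benzothiophen-2-yl and 2-chlorophenyl is at this place, and in which direction it runs.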